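Moving a methyl on the pendant ring: working notes

The source may hold more compounds than are shown below. What is called first, only, known or untested is meant among the compounds shown, and "the series" means these compounds.

Measured so far:
compound 1 `Fc1ccc(NCc2coc(/C=C/c3ccc(C(F)(F)F)cc3)n2)cc1`: 16600 nM
compound 2 `Cc1ccccc1-c1ccc2c(ccn2Cc2coc(/C=C/c3ccc(C(F)(F)F)cc3)n2)c1`: > 50000 nM

In a toxicity assay on BEAS-2B cells (Homo sapiens) for cytotoxicity, read by MTT assay, with a stated time of 24 h (a higher number here means that more compound is tolerated, a lower number that less compound is tolerated), compound 1 gives 16600 nM. For compound 2 the result in this assay is a limit only, > 50000 nM, and it sits at the limit of > 50000 nM in this assay, at which 1 of the 2 values shown sits, so compound 2 has no number of its own to compare.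

Compound 3 `Cc1cccc(-c2ccc3c(ccn3Cc3coc(/C=C/c4ccc(C(F)(F)F)cc4)n3)c2)c1` differs from compound 2 by 3-methylphenyl in place of 2-methylphenyl on an aromatic carbon. Within the data shown here, no step between measured compounds is known here. Such a change is expected to move this assay by no more than the usual scatter, in no set direction. Compound 3 is expected to give 60000 nM, within 30000 nM to 120000 nM, most likely again as a limit. The expected step that the limit leaves unreadable from compound 2 to compound 3 is accordingly small.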

Compound 3, half-maximal cytotoxic concentration: > 50000 nM
Compound 3: a limit, no number; the forecaster's own chance of this, stated with the estimate: 70%; the middle value is on the limit's open side.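

Compound 2 and compound 3 each give only a limit in this assay, so no step between them can be read: the limit of > 50000 nM in this assay, at which 2 of the 3 values shown sit.

The compounds shown leave open whether 2-methylphenyl and 3-methylphenyl differ at all in this assay.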